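Chain Variation on a Shared Lactone Core and Growth Inhibition

The compounds below may be only part of what the source reports. "The series", "measured", "known", "first", "only" and "open" are said of these compounds alone.

Compound 1 `CC(C)(C)C(=O)OCC1(CO)C/C(=C\CCCCCCCCCCCO)C(=O)O1`: > 10 ug/mL
Compound 2 `CCCCCOCCCCCCC/C=C1\CC(CO)(COC(=O)C(C)(C)C)OC1=O`: 9.52 ug/mL
Compound 3 `CC(=O)OCCCCCCCCCCCCCCC/C=C1\CC(CO)(COC(=O)C(C)(C)C)OC1=O`: > 10 ug/mL

Three compounds share one core and differ only in the long chain attached to it. In a functional assay on NCI-H322 cells (Homo sapiens) for antiproliferative activity (on this read-out higher numbers stand for weaker inhibition of growth and lower numbers for stronger inhibition of growth), compound 2 gives 9.52 ug/mL. For compound 1 the result is a limit of the assay, > 10 ug/mL. For compound 3 the result is likewise a limit, > 10 ug/mL. Among the measured compounds shown here, compound 2 thus carries the only number among the three, while the other two sit at the limit of > 10 ug/mL in this assay, at which 2 of the 3 values shown sit.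

Two measured steps start or end at compound 2: an at least 1.0-fold lower number from compound 1 to compound 2 (0.02 log units; that floor lies within the scatter) and an at least 1.0-fold higher number from compound 2 to compound 3 (0.02 log units; that floor lies within the scatter). Each reaches a limit on the far side, so each sets only a floor, and that floor lies within the scatter. The step that the two limits leave unreadable from compound 1 to compound 3 gives no readable size.

Compound 4 `CCCCCCCCC(O)CCCCCC/C=C1\CC(CO)(COC(=O)C(C)(C)C)OC1=O` has not yet been measured in this assay. It differs from compound 2 by 1-hydroxynonyl in place of (pentyloxy)methyl on a saturated chain carbon, six bonds along the chain from a double-bonded chain carbon. Since the steps from compound 2 to its neighbours reach only limits, no size beyond the scatter can be drawn from them. Compound 4 is therefore expected to sit close to compound 2, with a step of a 1.2-fold higher number from compound 2 to compound 4 (0.06 log units; within the scatter) expected and a fair chance of another limit. Compound 4 is estimated at 11 ug/mL, within a range from 5 ug/mL to 25 ug/mL.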

Compound 4, concentration for 50% growth inhibition: > 10 ug/mL
Compound 4: a limit, no number; the forecaster's own chance of this, stated with the estimate: 55%; the middle value is on the limit's open side.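

In this assay compound 4 gives > 10 ug/mL, which is a limit of the assay and not a number. Putting 1-hydroxynonyl, with its 1 hydrogen-bond donor, in place of (pentyloxy)methyl on a saturated chain carbon, six bonds along the chain from a double-bonded chain carbon, gives an at least 1.0-fold higher number from compound 2 to compound 4 (0.02 log units; that floor lies within the scatter), so this change, like the earlier ones, sets only a floor and shows no readable shift in growth inhibition. The step between compound 1 and compound 4 joins two limits and cannot be read, and compound 2 remains the only compound with a number, while the others now all sit at the same limit: the limit of > 10 ug/mL in this assay, at which 3 of the 4 values shown sit.

As far as these compounds go, whether a chain carrying an amine or a carboxylic acid, or a much shorter chain, would give a readable number in this assay stays open. Also open, from the compounds shown here alone, is how far compound 1, compound 3 and compound 4 lie past the limit, and so whether compound 2 truly differs from them at all.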